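This account rests on a few compounds, and the source may have more. Where it says the series, first, only, none or still open, it means among the compounds named here.

Three compounds have been measured in a functional assay (trachea) with Cavia porcellus as the target (on this read-out lower numbers stand for stronger inhibition and higher numbers for weaker inhibition), so far:

Compound 1 `CC(C)n1nc(-c2cccnc2)c2ccccc2c1=O` gives 3090 nM
Compound 2 `CCOC(=O)CCCn1nc(-c2cccnc2)c2ccccc2c1=O` gives 10000 nM
Compound 3 `O=c1c2ccccc2c(-c2cccnc2)nn1CCCCSc1ncccn1` gives 6170 nM

Compound 3 lies within the scatter of both compound 1 and compound 2, while those two stand apart, with a 3.2-fold higher number from compound 1 to compound 2 (0.51 log units; beyond the scatter) as the modest step that separates them.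

Compound 4 `O=c1c2ccccc2c(-c2cccnc2)nn1CCO` remains unmeasured. It differs from compound 3 by hydroxy in place of 2-((pyrimidin-2-yl)sulfanyl)ethyl on a saturated chain carbon, two bonds along the chain from an aromatic nitrogen and this amounts to hydroxy in place of 2-((pyrimidin-2-yl)sulfanyl)ethyl on a saturated chain carbon, two bonds along the chain from an aromatic nitrogen.

Both measured steps bear on this change, as each alters the group carried on the aromatic nitrogen. The larger one, already given, is modest. The other is a 1.6-fold lower number from compound 2 to compound 3 (0.21 log units; within the scatter) and stays within the scatter. Among the compounds with values here, no measured compound carries a hydroxy group, so the direction remains uncertain and the range must stay wide. No step beyond the scatter is therefore expected in this assay for this change. The estimate amounts to a 1.4-fold lower number from compound 3 to compound 4 (0.14 log units; within the scatter) as the expected step. For compound 4 the estimated value is 4500 nM with an expected range from 1600 nM to 12000 nM in this read-out.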

Compound 4, half-maximal inhibitory concentration: 4570 nM
Compound 4: middle estimate off by 1.0-fold (0.01 log units), on the low side, within the range that was stated.
By their numbers in this assay, from the lowest: compounds 1, 4, 3 and 2 (each within the scatter of the next, the first and the last beyond it).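

In this assay, the exchange on a saturated chain carbon, two bonds along the chain from an aromatic nitrogen, removes 2-((pyrimidin-2-yl)sulfanyl)ethyl, with its 9 heavy atoms and its six-membered aromatic ring, and puts a single hydroxy in its place, yet the number stays within the scatter, with a 1.4-fold lower number from compound 3 to compound 4 (0.13 log units; within the scatter). The same hydroxy does stand apart from the (ethoxycarbonyl)methyl it replaces at this place, with a 2.2-fold lower number from compound 2 to compound 4 (0.34 log units; beyond the scatter), a modest step and only the second beyond the scatter in this small set. Within the data shown here, no earlier compound carried a hydroxy, and 2-hydroxyethyl on the aromatic nitrogen cannot be told apart from isopropyl, with a 1.5-fold higher number from compound 1 to compound 4 (0.17 log units; within the scatter), so groups as different as these give numbers that lie close together in this assay.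

Nothing available accounts for why the ester differs from the hydroxy while the pyrimidine-bearing group does not. On these data alone, whether an amine or a carboxylic acid in place of the hydroxy, or a longer chain carrying the hydroxy, would move the number beyond the scatter from compound 4 remains open.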